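Methyl position on the aryl ring of the shared core

The source may report more compounds than this note shows. Statements on the series, on what has been measured and on what is new or still open speak of the compounds shown alone.

Measured so far in a functional assay on B16-F0 cells (Mus musculus) for inhibition, read by CCK-8 assay, with a stated time of 48 h; on this read-out higher numbers stand for weaker inhibition and lower numbers for stronger inhibition:
compound 1 `COc1cc(-c2ccnc3cc(-c4ccc(C)cc4)nn23)cc(OC)c1OC`, 21 nM
compound 2 `COc1cc(-c2ccnc3cc(-c4ccccc4)nn23)cc(OC)c1OC`, 4730 nM
compound 3 `COc1cc(-c2ccnc3cc(-c4ccc(C(F)(F)F)cc4)nn23)cc(OC)c1OC`, 1770 nM

Compound 1 gives the lowest number of the three; compound 3 sits nearest at an 84-fold higher number from compound 1 to compound 3 (1.93 log units; beyond the scatter) and compound 2 furthest at a 230-fold higher number from compound 1 to compound 2 (2.35 log units; beyond the scatter), both steps beyond the scatter. Between the two weaker compounds, a 2.7-fold lower number from compound 2 to compound 3 (0.43 log units; beyond the scatter) is modest.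

Compound 4 `COc1cc(-c2ccnc3cc(-c4cccc(C)c4)nn23)cc(OC)c1OC` differs from compound 1 as follows: 3-methylphenyl in place of 4-methylphenyl on an aromatic carbon

Within the data shown here, no measured step moves the methyl to another carbon of the ring; the measured steps remove it (a 230-fold higher number from compound 1 to compound 2 (2.35 log units; beyond the scatter)) or replace it by trifluoromethyl (an 84-fold higher number from compound 1 to compound 3 (1.93 log units; beyond the scatter)), and both are large losses. Among the measured compounds shown here, the only thing the data show is that 4-methylphenyl is the group present in the one strongly inhibiting compound, so a change to it is expected to cost something in this assay, though less than outright removal. The step from compound 1 to compound 4 is therefore expected to be an increase of about a 9.5-fold higher number from compound 1 to compound 4 (0.98 log units; beyond the scatter), with wide uncertainty. Compound 4 is estimated at 200 nM, in the range 30 nM to 2000 nM.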

Compound 4, half-maximal inhibitory concentration: 2220 nM
For compound 4 the middle estimate is 11-fold (1.05 log units) below the measured one; measured number above the stated range.
By their numbers in this assay, from the lowest: compound 1; then compounds 3 and 4 (each within the scatter of the next); then compound 2.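

In this assay the position of the methyl matters as well as its presence: 3-methylphenyl in place of 4-methylphenyl is a large change (a 110-fold higher number from compound 1 to compound 4 (2.02 log units; beyond the scatter)), so the low number of compound 1 does not carry over to an isomer with the same atoms. Compound 4 keeps only a modest gain from its methyl (a 2.1-fold lower number from compound 2 to compound 4 (0.33 log units; beyond the scatter)), and the remaining step (a 1.3-fold higher number from compound 3 to compound 4 (0.10 log units; within the scatter)) lies within the scatter, leaving 3-methylphenyl and 4-(trifluoromethyl)phenyl not separated by this read-out. Nothing available explains the effect of moving the methyl.

The compounds shown leave open whether ethyl, methoxy or chlorine in place of the methyl of 4-methylphenyl would preserve the low number of compound 1. They also do not show how an amine or a longer chain would fare there.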